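Adding a Third Methoxy Group to a Chalcone-Pyrazole Series

The source may hold more compounds than are shown below. What is called first, only, known or untested is meant among the compounds shown, and "the series" means these compounds.

Measured compounds:
compound 1, `COc1ccc(-c2cc(/C=C/C(=O)c3ccc(N)cc3)[nH]n2)cc1`: 45700 nM
compound 2, `COc1ccc(C(=O)/C=C/c2cc(-c3cc(OC)c(OC)c(OC)c3)n[nH]2)cc1OC`: 8590 nM
compound 3, `COc1ccc(-c2cc(/C=C/C(=O)c3ccc(N)cc3)[nH]n2)cc1OC`: 11200 nM

All three were tested in a functional assay on SF-268 cells (Homo sapiens) for inhibition, read by sulforhodamine B assay, with a stated time of 48 h; a lower number here means that less compound is tolerated, a higher number that more compound is tolerated. Compound 1 gives 45700 nM and compound 3 gives 11200 nM; the two differ in one place, (methoxy in place of hydrogen on an aromatic carbon), and the step of a 4.1-fold lower number from compound 1 to compound 3 (0.61 log units; beyond the scatter). Compound 2 gives 8590 nM, a number that sits close to that of compound 3 and further from that of compound 1; the difference between the cores of compound 1 and compound 2 is not broken down here.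

The unmeasured compound 4, `COc1cc(C(=O)/C=C/c2cc(-c3cc(OC)c(OC)c(OC)c3)n[nH]2)cc(OC)c1OC`, is made from compound 2 by the same kind of change: methoxy in place of hydrogen on an aromatic carbon. The surroundings of the place are not identical, since in compound 4 the entering group is also meta to a methoxy group, whereas in compound 3 it is only ortho to a methoxy group and meta to a large group.

Within the data shown here, because the earlier step of a 4.1-fold lower number from compound 1 to compound 3 (0.61 log units; beyond the scatter) moved the number down, a similar direction is expected here, though with less certainty since only one such step is known. For compound 4 the expected step is a 2.5-fold lower number from compound 2 to compound 4 (0.39 log units; beyond the scatter). Compound 4 is therefore estimated at 3500 nM in this assay, within a range from 1200 nM to 9000 nM.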

Compound 4, concentration lethal to 50% of the cells: 14200 nM
For compound 4 the middle estimate is 4.1-fold (0.61 log units) below the measured one, outside the stated range (above it).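

In this assay, adding the methoxy group gives a 1.7-fold higher number from compound 2 to compound 4 (0.22 log units; within the scatter), so on this core the change has no effect that can be told apart from the ordinary variation between repeated measurements. The same swap of hydrogen for methoxy therefore does not carry over with the same result from the core of compound 1 to the core of compound 2: the same change on two cores in this assay, a 4.1-fold lower number (0.61 log units; beyond the scatter) from compound 1 to compound 3 and a 1.7-fold higher number (0.22 log units; within the scatter) from compound 2 to compound 4, 6.7-fold (0.83 log units) apart, beyond the scatter of two such steps. What this does not show is which difference between the two pairs matters, since both the cores and the surroundings of the entering group differ, and one pair on each core is too little to support a general rule for the series.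

The compounds shown leave open whether a different group at this same place, such as a hydroxyl group or an ethoxy group, would follow the methoxy result on either core. They also leave open which part of the core sets the size of the step, a question that would need compounds differing from one another in only one place, and whether the contrast between the two cores holds in other cell lines.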